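The compounds below may be only part of what the source reports. "The series", "measured", "known", "first", "only" and "open" are said of these compounds alone.

In a functional assay on NCI/ADR-RES cells (Homo sapiens) for inhibition, read by sulforhodamine B assay, with a stated time of 48 h, tested at 10 uM (on this read-out lower numbers stand for less inhibition and higher numbers for more inhibition at the one concentration tested (going by the name of the read-out)), three compounds sharing one core have been measured. Compound 1, `Brc1cn2ccnc2c(-c2ccc3ncn(C4CCCCC4)c3c2)n1`, carries a bromo group on that core and gives 8.82%. Compound 2, `c1ccc(-c2cn3ccnc3c(-c3ccc4ncn(C5CCCCC5)c4c3)n2)cc1`, carries a phenyl at the same place and gives 50.5%. Compound 3, `COc1ccc(-c2cn3ccnc3c(-c3ccc4ncn(C5CCCCC5)c4c3)n2)cc1`, carries a 4-methoxyphenyl there and gives 87.2%, the highest of the three numbers, standing well above compound 2 and furthest from compound 1. All the steps among them are large: a number 41.7 percentage points higher from compound 1 to compound 2 (beyond the scatter), a number 78.4 percentage points higher from compound 1 to compound 3 (beyond the scatter) and a number 36.7 percentage points higher from compound 2 to compound 3 (beyond the scatter).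

Compound 4, `O=Cc1ccc(-c2cn3ccnc3c(-c3ccc4ncn(C5CCCCC5)c4c3)n2)cc1`, is the next to be measured in this assay. It differs from compound 3 in one place: formyl in place of methoxy on an aromatic carbon. Among the compounds with values here, the step that bears most directly on this change is the one from compound 2 to compound 3, where methoxy in place of hydrogen went with a large rise; that methoxy is now gone, so the rise seen with it cannot simply be assumed to carry over. Within the data shown here, no measured compound shows a formyl group, so the direction rests on the spread between compound 2 and compound 3. The expected step is a number 22.2 percentage points lower from compound 3 to compound 4 (beyond the scatter), a fall that may reach beyond the scatter. Compound 4 is therefore estimated to give 65%, within a range from 35% to 90%.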

Compound 4, a percentage reported as inhibition, at one concentration (the size of the read-out at that concentration, not a potency): 37.4%
Compound 4: the middle estimate sits 27.6 percentage points above what was measured; measured number inside the range.
By their numbers in this assay, from the lowest: compound 1; then compound 4; then compound 2; then compound 3.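

In this assay methoxy and formyl have the same heavy-atom count and sit in the same place, para to a large group, yet the exchange gives a number 49.8 percentage points lower from compound 3 to compound 4 (beyond the scatter) and so the group at this spot matters well beyond that count. The earlier compounds shown here showed only a rise when a group was added to the phenyl ring, whereas here formyl in place of hydrogen gives a number 13.1 percentage points lower from compound 2 to compound 4 (beyond the scatter) and so a group at this spot can also lower the number. The gain over the bromo compound survives this fall, with a number 28.6 percentage points higher from compound 1 to compound 4 (beyond the scatter) for 4-formylphenyl in place of bromo, so all three aryl compounds shown stand above compound 1.

No measurement at hand explains why methoxy and formyl give such different numbers. As far as these compounds go, how an amine, a hydroxy group or a carboxylic acid at the same place on the phenyl ring would compare with methoxy and formyl stays open, as does whether the two groups would keep their order on a different position of that ring.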